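The source may hold more compounds than are shown below. What is called first, only, known or untested is meant among the compounds shown, and "the series" means these compounds.

Working notes on the series. Of the compounds shown here, three have been measured in an assay on HEK293 cells for displacement of a labelled ligand from melanin-concentrating hormone receptor 1 (Homo sapiens); a higher number here means a weaker inhibitor, a lower number a stronger inhibitor. Compound 1 `O=C(NC1CCN(Cc2ccn(-c3ccc(C(F)(F)F)cc3)c2)CC1)N1CCC(c2ccccc2O)CC1` gives 36 nM. Compound 2 `COc1ccc(OC2CN(C(=O)NC3CCN(Cc4ccn(-c5ccc(C(F)(F)F)cc5)c4)CC3)C2)cc1` gives 49 nM. Compound 3 `O=C(NC1CCN(Cc2ccn(-c3ccc(C(F)(F)F)cc3)c2)CC1)N1CCCC1Cc1cccnc1` gives 26 nM. Compound 3 has the lowest of the three numbers, but its separation from compound 1 and from compound 2 lies within the scatter of repeated measurements, so the three read as equivalent and no order among them is claimed. Among the compounds with values here, none of the three pairs differs in only one place, so no single step can be extracted.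

Compound 4 `O=C(NC1CCN(Cc2ccn(-c3ccc(C(F)(F)F)cc3)c2)CC1)N1CC[C@@H](O)C1` is not yet measured. Against compound 3 the change is 3-hydroxypyrrolidin-1-yl in place of 2-((pyridin-3-yl)methyl)pyrrolidin-1-yl on a carbonyl carbon. The group that leaves carries an aromatic ring and two additional ring carbons; the group that enters is smaller by half and brings a hydroxyl donor. Within the data shown here, in compound 1, compound 2 and compound 3 the substituent on this carbonyl carbon always includes an aromatic ring, and compound 4 is the first without one. In the absence of a measured step of this kind, a loss in binding of appreciable size is expected, beyond the scatter, with wide uncertainty. The expected step from compound 3 to compound 4 is a 12-fold higher number from compound 3 to compound 4 (1.06 log units; beyond the scatter). For compound 4 in this assay the estimate is 300 nM, with a range from 60 nM to 1500 nM.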

Compound 4, half-maximal inhibitory concentration: 138 nM
For compound 4 the middle estimate is 2.2-fold (0.34 log units) above the measured one, within the range that was stated.
By their numbers in this assay, from the lowest: compounds 3, 1 and 2 (each within the scatter of the next); then compound 4.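

In this assay, within the data shown here, putting 3-hydroxypyrrolidin-1-yl in place of 2-((pyridin-3-yl)methyl)pyrrolidin-1-yl on a carbonyl carbon gives a 5.3-fold higher number from compound 3 to compound 4 (0.72 log units; beyond the scatter), the first single-place step and a modest one. This shows that the number responds to the group at this position, yet the six-membered aromatic ring of the leaving group is not needed for a measurable value, since compound 4 still gives 138 nM. The step changes the aromatic ring, the size of the group and the hydroxyl donor together, so it cannot be divided among them, and no separate measurement bears on what lies behind it.

A plain pyrrolidin-1-yl on this carbonyl carbon would separate the effect of losing the (pyridin-3-yl)methyl group from that of adding the hydroxyl. The compounds shown also leave open how the number would respond to the opposite configuration at the hydroxyl-bearing carbon, or to an amine or a methoxy group in place of the hydroxyl.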